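This account rests on a few compounds, and the source may have more. Where it says the series, first, only, none or still open, it means among the compounds named here.

Two compounds of the series have been run in a functional assay on A549 cells (Homo sapiens) for antiproliferative activity, read by CCK-8 assay, with a stated time of 72 h; on this read-out higher numbers stand for weaker inhibition and lower numbers for stronger inhibition. Compound 1 `CC1=NN(c2cccc(Cl)c2)C(=O)C12C=CC(=O)C=C2c1cccc(C)c1` gives 20100 nM. Compound 2 `CC1=NN(c2ccccc2)C(=O)C12C=CC(=O)C=C2c1cccc(C)c1` gives 16500 nM. Among the measured compounds shown here, the only measured step is a 1.2-fold lower number from compound 1 to compound 2 (0.09 log units; within the scatter), so compound 2 stands alongside compound 1 inside the usual scatter, and the two numbers cannot be told apart; on this read-out a halogen on the phenyl has so far made no difference that can be trusted.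

Compound 3 `CC1=NN(c2ccc(Br)cc2)C(=O)C12C=CC(=O)C=C2c1cccc(C)c1` is the next step out from compound 2. The change is bromo in place of hydrogen on an aromatic carbon, here para to a large group. For the measured compounds named here, the one step that bears on it, a halogen leaving an aromatic carbon of the same phenyl, stayed within the scatter, and no other halogen step is available. A second halogen entering the same phenyl is therefore expected to leave the number about where compound 2 sits, the step of a 1.0-fold higher number from compound 2 to compound 3 (0.01 log units; within the scatter) being expected to fall within the scatter, in no firm direction. Compound 3 is thus estimated at 17000 nM, with a range from 8000 nM to 40000 nM in this assay.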

Compound 3, half-maximal inhibitory concentration: 45400 nM
Estimate against measurement, compound 3: 2.7-fold (0.43 log units) below, outside the stated range (above it).
By their numbers in this assay, from the lowest: compounds 2 and 1 (each within the scatter of the next); then compound 3.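

In this assay, among the compounds shown here, the entry of bromo on the phenyl, para to a large group, gives a 2.8-fold higher number from compound 2 to compound 3 (0.44 log units; beyond the scatter) and is the first single change to pass beyond the scatter, a modest move towards weaker inhibition. The exchange of 3-chlorophenyl for 4-bromophenyl gives a 2.3-fold higher number from compound 1 to compound 3 (0.35 log units; beyond the scatter) and points the same way, so this phenyl is not indifferent to every halogen change, although compound 1 goes against any general rule that a halogen here weakens inhibition, its step being a 1.2-fold lower number from compound 1 to compound 2 (0.09 log units; within the scatter) and so within the scatter. Nothing measured in the compounds shown accounts for this shift.

The compounds shown do not separate the identity of the halogen from its place on the ring, as 4-chlorophenyl or 3-bromophenyl would be needed for a clean comparison with compound 3. Also open, from the compounds shown here alone, is whether any group at this place can bring the number below that of compound 2, with a methoxy group, an amine or a carboxylic acid on the phenyl as untested kinds of substituent in this set.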